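The source may report more compounds than this note shows. Statements on the series, on what has been measured and on what is new or still open speak of the compounds shown alone.

Of the compounds shown here, two built on the same core have been measured in a functional assay on RPTEC cells (Homo sapiens) for antiproliferative activity; on this read-out higher numbers stand for weaker inhibition of growth and lower numbers for stronger inhibition of growth. Compound 1 `c1ccc(-c2cc(-c3cccs3)cc(-c3ccncc3)n2)nc1` gives 0.65 ug/mL. Compound 2 `c1ccc(-c2cc(-c3ccoc3)cc(-c3ccccn3)n2)nc1` gives 0.0058 ug/mL. Compound 1 thus stands at the higher of the two numbers, and its distance from compound 2 lies well beyond the scatter of repeated measurements. Compound 3 `c1ccc(-c2cc(-c3cccs3)cc(-c3cccnc3)n2)nc1` differs from compound 1 in one place: pyridin-3-yl in place of pyridin-4-yl on an aromatic carbon. Going by the values given here, no pair of measured compounds shows what such a rearrangement does on its own, so the effect of the change can only be judged loosely. In this assay the expected step is a 1.3-fold lower number from compound 1 to compound 3 (0.11 log units; within the scatter), that is, a shift that may fall in either direction but is not expected to go beyond the usual scatter. Compound 3 is therefore estimated at about 0.5 ug/mL, with a likely range from 0.1 ug/mL to 3 ug/mL.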

Compound 3, concentration for 50% growth inhibition: 0.056 ug/mL
The estimate for compound 3 lay 8.9-fold (0.95 log units) above the measured number; the whole stated range lies above it.
By their numbers in this assay, from the lowest: compound 2; then compound 3; then compound 1.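

In this assay, pyridin-3-yl in place of pyridin-4-yl gives a 12-fold lower number from compound 1 to compound 3 (1.06 log units; beyond the scatter). This position, on an aromatic carbon next to the ring nitrogen, therefore distinguishes between two groups that match in every count of atoms, donors and acceptors, so the placement of the nitrogen within the group matters here, not merely its presence. Nothing available explains why the two isomers differ so sharply.

A single pair cannot show whether the same step would hold with a group other than thiophen-2-yl elsewhere on the core. On these data alone, it also remains open how this position would respond to a phenyl ring, which has no ring nitrogen, or to a pyridine ring bearing an amine or a methoxy group.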